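The source may report more compounds than this note shows. Statements on the series, on what has been measured and on what is new or still open speak of the compounds shown alone.

Measured compounds:
compound 1, `Cc1cccc([C@@H](O)C(=O)N2N=CC[C@H]2C(=O)NCc2cc(Cl)ccc2-n2cnnn2)c1`, in an ADME assay on liver for metabolic stability, with Liver microsome (Homo sapiens) as the target, read by LC-MS, using microsomes; on this read-out lower numbers stand for slow clearance and higher numbers for fast clearance: < 12 mL.min-1.g-1
compound 2, `O=C(NCc1cc(Cl)ccc1-n1cnnn1)[C@@H]1C[C@H]2C[C@H]2N1C(=O)[C@H](O)c1cccc(F)c1`, in this assay: 32 mL.min-1.g-1

In this assay compound 1 gives only a limit, not a number, namely (the limit of < 12 mL.min-1.g-1 in this assay, at which 1 of the 2 values shown sits). Compound 3, `COC(C)(C)[C@@H](O)C(=O)N1N=CC[C@H]1C(=O)NCc1cc(Cl)ccc1-n1cnnn1`, differs from compound 1 by 1-methoxy-1-methylethyl in place of 3-methylphenyl on a saturated chain carbon bound to a carbonyl carbon and an oxygen on a saturated carbon. Going by the values given here, no measured pair shows this change, so nothing here fixes its effect; compound 3 is expected to sit near compound 1, with a step no larger than the usual scatter, an at least 1.2-fold higher number from compound 1 to compound 3 (0.09 log units; that floor lies within the scatter). Compound 3 is therefore estimated to give 15 mL.min-1.g-1, within a range from 6 mL.min-1.g-1 to 40 mL.min-1.g-1.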

Compound 3, intrinsic clearance in microsomes: < 12 mL.min-1.g-1
Compound 3: a limit, no number (the forecaster's own chance of this, stated with the estimate: 40%); at least 1.2-fold (0.09 log units) between middle value and limit.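

No step can be read between compound 1 and compound 3, because both give only a limit in this assay: the limit of < 12 mL.min-1.g-1 in this assay, at which 2 of the 3 values shown sit.

On these data alone, what 1-methoxy-1-methylethyl in place of 3-methylphenyl does to clearance therefore remains open.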